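The source may hold more compounds than are shown below. What is called first, only, known or untested is meant among the compounds shown, and "the series" means these compounds.

Compound 1 `CC(C)(O)c1ccc(-c2cnc3c(n2)N(CC2CCOCC2)C(=O)CN3)cn1`: 81%
Compound 2 `CO[C@H]1CC[C@@H](N2CC(=O)Nc3ncc(-c4ccc(C(C)(C)O)nc4)nc32)CC1`: 59%

Of the compounds shown here, two have been measured in a functional assay on the whole organism (PC-3 cells) for inhibition, with Mus musculus as the target, in a xenograft, with a stated time of 8 h, at a dose of 100 mg/kg by the oral route; a higher number here means more inhibition at the dose given (going by the name of the read-out), a lower number less inhibition. Compound 1 gives 81%, while compound 2 gives 59%, which is the lower of the two numbers; compound 1 stands higher by a difference that lies beyond the usual scatter of this assay. Going by the values given here, no step between compounds that differ in only one place has been measured, so the two values show only where each compound stands, not what a single change does.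

Compound 3 `CO[C@H]1CC[C@H](N2CC(=O)Nc3ncc(-c4ccc(C(C)(C)O)nc4)nc32)CC1` has not yet been measured in this assay. It is related to compound 2 as follows: the two compounds have the same atoms and bonds and differ only in configuration as drawn: 2 of 2 stereo elements differ (all stereocentres are inverted: mirror images); a stereocentre at a saturated ring carbon is drawn s in compound 2 and r in compound 3; a stereocentre at a saturated ring carbon is drawn s in compound 2 and r in compound 3.

Among the compounds with values here, nothing among the measured compounds shows what inverting the configuration does in this assay, so no direction can be derived, and a change of any size, or none beyond the scatter, remains possible. Compound 3 is therefore estimated to give 55%, with a range of 20% to 85%, which means an expected step of a number 4 percentage points lower from compound 2 to compound 3 (within the scatter).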

Compound 3, a percentage reported as inhibition, in the whole organism at one dose (the size of the read-out at that dose, not a potency): 69%
Beside the measured number, compound 3's estimate is 14 percentage points below it, and the stated range covers the measured number.
By their numbers in this assay, from the lowest: compounds 2 and 3 (each within the scatter of the next); then compound 1.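

Inverting both stereocentres at saturated ring carbons gives, in this assay, a number 10 percentage points higher from compound 2 to compound 3 (within the scatter). Going by these compounds alone, this is the first comparison here that can be read as a single change, and the step can be placed on configuration alone because nothing else separates the pair: the fact that compounds 2 and 3 differ only in the configuration as drawn. For this pair, the configuration as drawn therefore does not shift the inhibition at the dose given beyond the scatter of this assay, so neither configuration can be preferred over the other on these numbers.

What the compounds leave open is how a different group on the saturated ring, such as an amine or a carboxylic acid, would behave, as compounds 2 and 3 carry the same atoms and show only the effect of configuration. Within the data shown here, it also remains open which structural change separates compound 1, at 81%, from this pair, as no step links it to either compound and the inverted pair says nothing about that gap.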